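Triazole substituent variation and single-dose cytotoxicity

A few compounds are considered here, and "the series" means these few. Any claim that something is new, unique, unknown or untested is made for them only; others in the source may bear on it.

Measured so far:
compound 1 `CCCCCCCCc1cn(C(c2ccccc2)c2cc3cc(Br)ccc3nc2OC)nn1`: 2.27%
compound 2 `COc1nc2ccc(Br)cc2cc1C(c1ccccc1)n1cc(CO)nn1`: 4.65%

In an ADME assay on PC-3 cells (Homo sapiens) for cytotoxicity, read by sulforhodamine B assay, with a stated time of 48 h, tested at 10 uM (a lower number here means less inhibition, a higher number more inhibition at the concentration tested (going by the name of the read-out)), compound 1 gives 2.27%. In the same test compound 2 gives 4.65%. The two numbers are both low, and the step of a number 2.4 percentage points higher from compound 1 to compound 2 (within the scatter) lies within the scatter, so compound 2 cannot be separated from compound 1; both numbers read as level at the concentration tested.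

Compound 3 `COc1nc2ccc(Br)cc2cc1C(c1ccccc1)n1cc(-c2ccccc2C(F)(F)F)nn1` differs from compound 2 at the same position of the shared core: 2-(trifluoromethyl)phenyl in place of hydroxymethyl on an aromatic carbon. Among the measured compounds shown here, the only step measured, a number 2.4 percentage points higher from compound 1 to compound 2 (within the scatter), also exchanged the group on that five-membered aromatic ring, replacing heptyl with hydroxy, and it did not move the read-out beyond the scatter. For the measured compounds named here, there is no measured step involving an aromatic replacement on that ring, so the expectation rests on this single comparison alone.

On that basis the step from compound 2 to compound 3 is expected to be small, a number 3.4 percentage points higher from compound 2 to compound 3 (within the scatter), in either direction or none beyond the scatter. Compound 3 is therefore estimated at 8%, within -5% to 28%.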

Compound 3, a percentage reported as inhibition, at one concentration (the size of the read-out at that concentration, not a potency): 17.4%
For compound 3 the middle estimate is 9.4 percentage points below the measured one; low and high end bracket the measured number.
By their numbers in this assay, from the lowest: compounds 1 and 2 (each within the scatter of the next); then compound 3.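

Among the compounds shown here, on the aromatic carbon of the five-membered aromatic ring, 2-(trifluoromethyl)phenyl in place of hydroxymethyl is the first change at this position to move the read-out in this assay beyond the scatter, with a number 12.8 percentage points higher from compound 2 to compound 3 (beyond the scatter), and 2-(trifluoromethyl)phenyl in place of octyl gives a number 15.1 percentage points higher from compound 1 to compound 3 (beyond the scatter). The position can therefore register a change in this assay, whereas the two compounds without an aromatic ring at this carbon could not be told apart, at a number 2.4 percentage points higher from compound 1 to compound 2 (within the scatter); among these three compounds, only compound 3 stands apart, and its single-concentration reading of 17.4% is still a modest one. No measurement available here accounts for the difference between compound 3 and the other two compounds.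

Still open, going by these compounds, is whether the step belongs to the aromatic ring itself or to the trifluoromethyl on it, a question that a plain phenyl at the same carbon would address. Also open, on these data alone, is how an amine or a carboxylic acid at this position would read in this assay, and whether a second aromatic group would match compound 3.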